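Swapping the piperazine on compound 1 for a methoxyazetidine

The source may hold more compounds than are shown below. What is called first, only, known or untested is meant among the compounds shown, and "the series" means these compounds.

Measured so far:
compound 1, `COC(=O)C1=C(CN2CCNCC2)NC(c2nccs2)=NC1(C)c1ccc(F)cc1`, 39 mL/min/kg
compound 2, `COC(=O)C1=C(CN2CCNC(=O)C2)NC(c2nccs2)=NC1(C)c1ccc(F)cc1`, 81 mL/min/kg

In an ADME assay on microsomes from liver (Mus musculus) for metabolic stability, read by LC-MS, using NADPH, with stated times of 10 min and 30 min, tested at 1 uM (on this read-out lower numbers stand for slow clearance and higher numbers for fast clearance), compound 1 gives 39 mL/min/kg, the lowest of the two numbers recorded; the nearest is compound 2, a 2.1-fold higher number from compound 1 to compound 2 (0.32 log units; beyond the scatter).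

Compound 3, `COC(=O)C1=C(CN2CC(OC)C2)NC(c2nccs2)=NC1(C)c1ccc(F)cc1`, has not yet been measured in this assay. It differs from compound 1 in one place: 3-methoxyazetidin-1-yl in place of piperazin-1-yl on a saturated chain carbon bound to a double-bonded ring carbon.

Going by the values given here, the only measured step that touches this place is the one from compound 1 to compound 2, where the piperazin-1-yl was altered rather than replaced, and the number moved modestly, a 2.1-fold higher number from compound 1 to compound 2 (0.32 log units; beyond the scatter). Among the compounds with values here, a second change at the same point, this time to a 3-methoxyazetidin-1-yl, has no direct precedent here, so a step of similar modest size is expected, most likely upward, a 1.5-fold higher number from compound 1 to compound 3 (0.19 log units; within the scatter). Compound 3 is therefore estimated at 60 mL/min/kg, with a range from 28 mL/min/kg to 130 mL/min/kg.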

Compound 3, clearance: 88 mL/min/kg
Compound 3: the middle estimate sits 1.5-fold (0.17 log units) below what was measured; low and high end bracket the measured number.
By their numbers in this assay, from the lowest: compound 1; then compounds 2 and 3 (each within the scatter of the next).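

In this assay, the four-membered 3-methoxyazetidin-1-yl on this saturated chain carbon gives a 2.3-fold higher number from compound 1 to compound 3 (0.35 log units; beyond the scatter), so a second replacement, with a different ring size, also leaves piperazin-1-yl with the lowest number of the three. The two replacements cannot be told apart, with a 1.1-fold higher number from compound 2 to compound 3 (0.04 log units; within the scatter), even though 3-oxopiperazin-1-yl keeps the six-membered ring and 3-methoxyazetidin-1-yl does not. No measurement shown here explains the rise at this position.

The compounds shown leave open whether the higher number goes with the four-membered ring or with the methoxy group, which a plain azetidin-1-yl on the same carbon would help separate. They also leave open whether other six-membered rings, such as morpholin-4-yl or 4-methylpiperazin-1-yl, would stay close to compound 1 or move towards compounds 2 and 3.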